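The source may hold more compounds than are shown below. What is called first, only, known or untested is meant among the compounds shown, and "the series" means these compounds.

Measured so far:
compound 1 `O=C1OC(c2ccc(Cl)cc2)=C/C1=C\c1ccccc1` — 36%
compound 2 `O=C1OC(c2ccc(Cl)cc2)=C/C1=C\c1ccccc1Cl` — 81.5%

In a functional assay on the whole organism (strain Wistar) for inhibition, with Rattus norvegicus as the target, with stated times of 30 min and 3 h, at a dose of 20 mg/kg by the oral route (a lower number here means less inhibition, a higher number more inhibition at the dose given (going by the name of the read-out)), compound 2 stands highest of the two numbers, with compound 1 the nearer and only other point. For the measured compounds named here, the single measured step, a number 45.5 percentage points higher from compound 1 to compound 2 (beyond the scatter), is large and beyond the scatter. Compound 3 `O=C1OC(c2ccc(Cl)cc2)=C/C1=C\c1ccc(Cl)cc1` differs from compound 2 by 4-chlorophenyl in place of 2-chlorophenyl on a double-bonded chain carbon bound to a double-bonded ring carbon. Going by the values given here, no measured step bears directly on moving a chloro within the ring; the step from compound 1 to compound 2 shows only that adding chloro helped. Compound 3 keeps a chloro, so a value between compound 1 and compound 2 is expected, with a step of a number 21.5 percentage points lower from compound 2 to compound 3 (beyond the scatter) in this assay. The estimate for compound 3 is 60%, between 30% and 85%.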

Compound 3, a percentage reported as inhibition, in the whole organism at one dose (the size of the read-out at that dose, not a potency): 69.1%
Compound 3: the middle estimate sits 9.1 percentage points below what was measured; low and high end bracket the measured number.
By their numbers in this assay, from the lowest: compound 1; then compound 3; then compound 2.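

In this assay, chloro in place of hydrogen on an aromatic carbon also pays off in the 4-chlorophenyl form, with a number 33.1 percentage points higher from compound 1 to compound 3 (beyond the scatter), so the gain is not confined to 2-chlorophenyl. The place of the chloro on this ring still counts: 4-chlorophenyl in place of 2-chlorophenyl gives a number 12.4 percentage points lower from compound 2 to compound 3 (beyond the scatter), leaving 2-chlorophenyl the better of the two. No evidence at hand accounts for this difference.

Open, going by these compounds, is whether a methoxy group or an amine on this ring would follow the same order as chloro.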